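A few compounds are considered here, and "the series" means these few. Any claim that something is new, unique, unknown or untested is made for them only; others in the source may bear on it.

Measured compounds:
- compound 1, `O=C1CCc2ccc(OCc3cccc(Cl)c3)cc2N1`, in an assay on isolated protein for inhibition of Amine oxidase [flavin-containing] A (Homo sapiens), read by fluorescence, with a stated time of 15 min (on this read-out higher numbers stand for weaker inhibition and lower numbers for stronger inhibition), gives > 100000 nM; this is a limit of the assay, not a number.
- compound 2, `O=C1OCc2cc(OCc3ccc(C(F)(F)F)cc3)ccc21`, in this assay gives 9240 nM.
- compound 3, `O=c1ccoc2cc(OCc3ccc(C(F)(F)F)cc3)ccc12`, in this assay gives 18900 nM.

Going by the values given here, only two of the three compounds give a number at all, and of those two compound 2 has the lower one, which on this read-out means the stronger inhibition. Compound 3 sits beyond the usual scatter above it. Compound 1 reaches only the limit of the assay (the limit of > 100000 nM in this assay, at which 1 of the 3 values shown sits), so it says nothing about the size of any step.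

Compound 4, `O=C1OCc2cc(OCc3ccc(F)cc3)ccc21`, differs from compound 2 in a single place: fluoro in place of trifluoromethyl on an aromatic carbon. Among the compounds with values here, no measured pair here shows a swap of this kind, so there is no directly comparable step to lean on. The trifluoromethyl group of compound 2 is replaced by the much smaller fluoro group, and the expectation is a modest move toward weaker inhibition, a step that may well stay within the usual scatter of repeated measurements, as a 1.6-fold higher number from compound 2 to compound 4 (0.21 log units; within the scatter) in this assay expresses. Compound 4 is therefore estimated at 15000 nM, with a plausible range from 5000 nM to 60000 nM.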

Compound 4, half-maximal inhibitory concentration: 1330 nM
Compound 4: middle estimate off by 11-fold (1.05 log units), on the high side, outside the stated range (below it).
By their numbers in this assay, from the lowest: compound 4; then compound 2; then compound 3. At a limit, above all of these: compound 1.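

In this assay, going by these compounds alone, the swap of trifluoromethyl for fluoro on an aromatic carbon, para to a large group, gives the first step that can be read between two compounds differing in one place: a 6.9-fold lower number from compound 2 to compound 4 (0.84 log units; beyond the scatter). It shows that inhibition responds to what sits at this position, and that fluoro, with 1 heavy atom, goes with stronger inhibition here than trifluoromethyl, with 4 heavy atoms, on the shared core. None of the values shown says why the number moves in this direction.

As far as these compounds go, one swap at one position gives only two points, so it remains open whether a methoxy group, a nitrile or a plain hydrogen at this carbon would give a lower number still or a higher one, and whether the number follows the count of heavy atoms at all. From the compounds shown here alone, it also remains open whether fluoro in place of trifluoromethyl would give a step of similar size on the core of compound 3, or whether this step belongs to the core of compound 2 alone.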